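Acetyl for fluoro on a shared core

The source may hold more compounds than are shown below. What is called first, only, known or untested is meant among the compounds shown, and "the series" means these compounds.

Compound 1 `Brc1cn2ccnc2c(-c2ccc3ncn(C4CCCCC4)c3c2)n1`: 16.1%
Compound 2 `Fc1ccc(-c2cn3ccnc3c(-c3ccc4ncn(C5CCCCC5)c4c3)n2)cc1`: 17.6%

In a functional assay on Hs-578T cells (Homo sapiens) for inhibition, read by sulforhodamine B assay, with a stated time of 48 h, tested at 10 uM (on this read-out higher numbers stand for more inhibition at the one concentration tested (going by the name of the read-out) and lower numbers for less inhibition), compound 2 gives 17.6%. Of the two numbers shown it is the one nearest the top, but the step of a number 1.5 percentage points higher from compound 1 to compound 2 (within the scatter) lies within the scatter, so compound 1 and compound 2 cannot be told apart. Compound 3 `CC(=O)c1ccc(-c2cn3ccnc3c(-c3ccc4ncn(C5CCCCC5)c4c3)n2)cc1` differs from compound 2 by acetyl in place of fluoro on an aromatic carbon. For the measured compounds named here, the only measured step, a number 1.5 percentage points higher from compound 1 to compound 2 (within the scatter), concerned a different position and stayed within the scatter; no step swaps one group for another on that phenyl. The step of a number 0.4 percentage points higher from compound 2 to compound 3 (within the scatter) is therefore expected to be none beyond the scatter. Compound 3 is estimated at 18%, within 4% to 36%.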

Compound 3, a percentage reported as inhibition, at one concentration (the size of the read-out at that concentration, not a potency): 6.34%
Beside the measured number, compound 3's estimate is 11.7 percentage points above it; measured number inside the range.
By their numbers in this assay, from the lowest: compounds 3, 1 and 2 (each within the scatter of the next, the first and the last beyond it).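

In this assay, for the compounds shown here, acetyl in place of fluoro on an aromatic carbon, para to a large group, gives a number 11.3 percentage points lower from compound 2 to compound 3 (beyond the scatter), the first step here to pass the scatter, so the group at this position can matter. With 4-acetylphenyl in place of bromo the step is a number 9.8 percentage points lower from compound 1 to compound 3 (within the scatter), so the change is resolved only against 4-fluorophenyl. Nothing at hand bears on the reason for this step. Still open, going by these compounds, is how an amine or a carboxylic acid in place of acetyl on that phenyl would read.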